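Exchanging the Para Ester for an Ethyl Tetrazole

The source may hold more compounds than are shown below. What is called first, only, known or untested is meant among the compounds shown, and "the series" means these compounds.

Compound 1 `CCn1c(CNc2ccccc2)nnc1SCC(=O)Nc1ccc(Cl)cc1` was tested in an assay on isolated protein for inhibition of long-chain fatty acid transport protein 1 (Homo sapiens); on this read-out higher numbers stand for weaker inhibition and lower numbers for stronger inhibition; for compound 1 the result is only a limit of the assay, > 1000 nM. Compound 2 `CCn1c(CNc2ccccc2)nnc1SCC(=O)Nc1ccc(C(=O)OC)cc1` gives 540 nM, and compound 3 `CCOC(=O)c1ccc(NC(=O)CSc2nnc(CNc3ccccc3)n2CC)cc1` gives 330 nM. The steps of an at least 1.8-fold lower number from compound 1 to compound 2 (0.26 log units; that floor lies within the scatter) and an at least 3.0-fold lower number from compound 1 to compound 3 (0.48 log units; beyond the scatter) both start from that limit, while a 1.6-fold lower number from compound 2 to compound 3 (0.21 log units; within the scatter) stays within the scatter. Compound 3 sits at the lower of the two plain numbers, though the gap to compound 2 does not separate them. Compound 4 `CCn1nnc(-c2ccc(NC(=O)CSc3nnc(CNc4ccccc4)n3CC)cc2)n1` differs from compound 3 by 2-ethyl-2H-tetrazol-5-yl in place of ethoxycarbonyl on an aromatic carbon. Among the measured compounds shown here, only the steps from compound 1 bear on changes at that aromatic carbon, and both show groups other than chloro giving lower numbers; the new group itself is untested. Compound 4 is expected to give a similar number, with a 1.2-fold higher number from compound 3 to compound 4 (0.08 log units; within the scatter), an estimate of 400 nM and a range from 150 nM to 1200 nM.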

Compound 4, half-maximal inhibitory concentration: > 1000 nM
Compound 4: no number, only a limit; the forecaster's own chance of this, stated with the estimate: 20%; middle value at least 2.5-fold (0.39 log units) from the limit.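

Among the compounds shown here, at this aromatic carbon, the earlier compounds showed only that two esters gave lower numbers than chloro; the step to 2-ethyl-2H-tetrazol-5-yl now shows that this does not extend to every replacement, with an at least 3.0-fold higher number from compound 3 to compound 4 (0.48 log units; beyond the scatter) in this assay. The comparison with the methyl ester is less firm, at an at least 1.8-fold higher number from compound 2 to compound 4 (0.26 log units; that floor lies within the scatter). The step between compound 1 and compound 4 cannot be read, since both values are limits: the limit of > 1000 nM in this assay, at which 2 of the 4 values shown sit.

The compounds shown leave open whether a carboxylic acid, a primary amide or a propyl ester at this carbon would give numbers like those of compound 2 and compound 3.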